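Indazole esters: benzyl to butyl on the ring nitrogen

This account rests on a few compounds, and the source may have more. Where it says the series, first, only, none or still open, it means among the compounds named here.

Measured so far
Compound 1 `CCOC(=O)c1cccc(-c2n[nH]c3ccccc23)c1`: > 10000 nM in a functional assay on cells (Platelet, Homo sapiens) for inhibition; a lower number here means a stronger inhibitor, a higher number a weaker inhibitor
Compound 2 `CCOC(=O)c1ccc(-c2nn(Cc3cccc(OC)c3)c3ccccc23)cc1`: > 10000 nM in this assay

Both values are limits of the assay, not numbers. For compound 2 only a limit is known in this assay. Both recorded values sit at that limit (the limit of > 10000 nM in this assay, at which 2 of the 2 values shown sit), so no ordering of compound 1 and compound 2 can be read from them.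

Compound 3 `CCCCn1nc(-c2ccc(C(=O)OCC)cc2)c2ccccc21` is unmeasured. It differs from compound 2 by propyl in place of 3-methoxyphenyl on a saturated chain carbon bound to an aromatic nitrogen. No measured step among these compounds informs this change; the expected step is a step that the limit leaves unreadable from compound 2 to compound 3, within the scatter. Compound 3 is estimated at 15000 nM, range 5000 nM to 50000 nM, most likely again reported as a limit.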

Compound 3, half-maximal inhibitory concentration: > 10000 nM
Compound 3: only a limit was reported; the forecaster's own chance of this, stated with the estimate: 80%; the middle value is on the limit's open side.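

No step can be read from compound 2 to compound 3, as both values are limits of the assay: the limit of > 10000 nM in this assay, at which 3 of the 3 values shown sit.

The compounds shown leave open whether in this assay any group at this place gives a value inside that limit.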